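A few compounds are considered here, and "the series" means these few. Any claim that something is new, unique, unknown or untested is made for them only; others in the source may bear on it.

Measured in an ADME assay on microsomes from liver (Homo sapiens) for metabolic stability; on this read-out higher numbers stand for a longer-lived compound and lower numbers for a shorter-lived compound:
compound 1, `COc1cc(OCc2cccc(-c3cnc(OC)nc3)c2)c2cc(-c3cn4nc(OC)sc4n3)oc2c1`, gives 0.6 h;
compound 2, `CNC(=O)c1ccc(-c2nc(COc3cc(OC)cc4oc(-c5cn6nc(OC)sc6n5)cc34)cs2)cc1`, gives 0.983 h;
compound 3, `COc1cc(OCc2csc(-c3ccc(C(F)(F)F)cc3)n2)c2cc(-c3cn4nc(OC)sc4n3)oc2c1`, gives only a limit of the assay, > 2 h.

Compound 1 holds the lowest of the two plain numbers, and compound 2, the nearest, sits within the usual scatter of it. Compound 4, `COc1cc(OCc2cccc(OCc3ccccc3)c2)c2cc(-c3cn4nc(OC)sc4n3)oc2c1`, differs from compound 1 by benzyloxy in place of 2-methoxypyrimidin-5-yl on an aromatic carbon. For the measured compounds named here, the single measured step, an at least 2.0-fold higher number from compound 2 to compound 3 (0.30 log units; that floor lies within the scatter), swaps a different group on a different ring, so it bears only loosely on this exchange and no other step matches it. Compound 4 is therefore expected to stay close to compound 1, with a step of a 1.2-fold higher number from compound 1 to compound 4 (0.07 log units; within the scatter), not beyond the scatter. The estimate for compound 4 is 0.7 h, within a range from 0.35 h to 1.5 h.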

Compound 4, half-life: 1.43 h
Compound 4: the middle estimate sits 2.0-fold (0.31 log units) below what was measured; measured number inside the range.
By their numbers in this assay, from the lowest: compounds 1, 2 and 4 (each within the scatter of the next, the first and the last beyond it). At a limit, above all of these: compound 3.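

For the compounds shown here, compounds 1 and 4 give the first reading at this position, on an aromatic carbon meta to a large group: benzyloxy in place of 2-methoxypyrimidin-5-yl gives a 2.4-fold higher number from compound 1 to compound 4 (0.38 log units; beyond the scatter). The half-life therefore responds to this exchange, though only modestly. Both groups hold the same count of heavy atoms, so that count does not separate them, while the ring hetero atoms and hydrogen-bond acceptors differ.

From the compounds shown here alone, whether the ring nitrogens or the oxygen link matters stays open, and a plain phenyl or an amine here could help separate them. Compound 3 stands at a limit of the assay, not at a number: the limit of > 2 h in this assay, at which 1 of the 4 values shown sits.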